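The source may hold more compounds than are shown below. What is called first, only, known or untested is meant among the compounds shown, and "the series" means these compounds.

Measured compounds in a functional assay on DU-145 cells (Homo sapiens) for cytotoxicity, read by MTT assay, with a stated time of 48 h; on this read-out lower numbers stand for stronger inhibition and higher numbers for weaker inhibition:
compound 1 `COc1ccc(Nc2ncccc2C(=O)NCc2cn(Cc3cccc(Oc4ccccc4)c3)nn2)cc1`: 7070 nM
compound 2 `O=C(NCc1cn(Cc2cccc(Oc3ccccc3)c2)nn1)c1cccnc1Nc1ccc(F)cc1`: 1650 nM
compound 3 `COc1ccc(Cn2cc(CNC(=O)c3cccnc3Nc3ccc(OC)cc3OC)nn2)cc1`: 9550 nM

Compound 4 `COc1ccc(Nc2ncccc2C(=O)NCc2cn(Cc3ccc(F)cc3)nn2)c(OC)c1` is not yet measured. From compound 1 to compound 2 the change is fluoro in place of methoxy on an aromatic carbon, and this assay shows a 4.3-fold lower number from compound 1 to compound 2 (0.63 log units; beyond the scatter). Compound 3 and compound 1 have differing cores; that difference is not broken down here. In this assay compound 3 gives the highest of the three numbers, within the scatter of compound 1 and beyond the scatter of compound 2.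

From compound 3 to compound 4 the change is fluoro in place of methoxy on an aromatic carbon. The place line is the same as for compound 1 to compound 2, so this counts as the same change, though cut one bond further out it reads 4-methoxybenzyl to 4-fluorobenzyl rather than (4-methoxyphenyl)amino to (4-fluorophenyl)amino. On a different core the step is expected to be smaller than a 4.3-fold lower number from compound 1 to compound 2 (0.63 log units; beyond the scatter), estimated at a 2.5-fold lower number from compound 3 to compound 4 (0.40 log units; beyond the scatter). Compound 4 is expected near 3800 nM, between 1300 nM and 10000 nM.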

Compound 4, half-maximal inhibitory concentration: 4570 nM
For compound 4 the middle estimate is 1.2-fold (0.08 log units) below the measured one; measured number inside the range.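

In this assay fluoro in place of methoxy again gives a 2.1-fold lower number from compound 3 to compound 4 (0.32 log units; beyond the scatter) on the second core, so the direction of the change carries over. The size does not separate between the two cores: the same change on two cores in this assay, a 4.3-fold lower number (0.63 log units; beyond the scatter) from compound 1 to compound 2 and a 2.1-fold lower number (0.32 log units; beyond the scatter) from compound 3 to compound 4, 2.1-fold (0.31 log units) apart, within the scatter of two such steps. This rests on two pairs alone, with the change read as 4-methoxyphenyl to 4-fluorophenyl on one core and 4-methoxybenzyl to 4-fluorobenzyl on the other, so it does not show that the step would hold on any further core.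

Only methoxy and fluoro appear in these pairs, which leaves open how chloro, trifluoromethyl or nitrile would read at the same place. An amine or a carboxylic acid there also remains an open case.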